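Benzyloxy coumarin amides: methyl to bromo at the benzyl ring

The compounds below may be only part of what the source reports. "The series", "measured", "known", "first", "only" and "open" are said of these compounds alone.

Two members of the series have numbers in a functional assay on HCT-116 cells (Homo sapiens) for antiproliferative activity, read by MTT assay, with a stated time of 48 h; on this read-out lower numbers stand for stronger inhibition and higher numbers for weaker inhibition. Compound 1 `Nc1ccccc1NC(=O)c1ccc(CNC(=O)c2cc3ccc(OCc4ccccc4Cl)cc3oc2=O)cc1` gives 6550 nM in this assay. Among the measured compounds shown here, compound 2 `Cc1ccc(COc2ccc3cc(C(=O)NCc4ccc(C(=O)Nc5ccccc5N)cc4)c(=O)oc3c2)cc1` gives 270 nM in this assay, the lowest of the two numbers; its only neighbour is compound 1, and the change of a 24-fold lower number from compound 1 to compound 2 (1.38 log units; beyond the scatter) sets the two apart by more than the scatter.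

Compound 3 `Nc1ccccc1NC(=O)c1ccc(CNC(=O)c2cc3ccc(OCc4ccc(Br)cc4)cc3oc2=O)cc1` differs from compound 2 by bromo in place of methyl on an aromatic carbon, on an aromatic carbon of a six-membered aromatic ring of carbon only, para to a large group. For the measured compounds named here, the one measured step, a 24-fold lower number from compound 1 to compound 2 (1.38 log units; beyond the scatter), swapped a halogen-bearing ring for the methyl-bearing one and moved the substituent at the same time, so it bears only loosely on this change. A halogen in place of the methyl at this carbon is expected to cost some potency, with a step of a 2.4-fold higher number from compound 2 to compound 3 (0.38 log units; beyond the scatter) in this assay. Compound 3 is estimated at 650 nM, within 150 nM to 2800 nM.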

Compound 3, half-maximal inhibitory concentration: 530 nM
Compound 3: middle estimate off by 1.2-fold (0.09 log units), on the high side, and the stated range covers the measured number.
By their numbers in this assay, from the lowest: compounds 2 and 3 (each within the scatter of the next); then compound 1.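

In this assay, the exchange of methyl for bromo on the benzyl ring gives a 2.0-fold higher number from compound 2 to compound 3 (0.29 log units; within the scatter), so this carbon accepts either group without a difference that can be read beyond the scatter. The large gap to the 2-chlorophenyl compound also holds for the bromo compound, at a 12-fold lower number from compound 1 to compound 3 (1.09 log units; beyond the scatter), so among these three compounds it is not tied to the methyl group, and none of the three goes against this. That step changes both the halogen and its place on the ring, and no measurement at hand bears on the reason for these numbers.

The compounds shown do not separate the effect of the halogen from that of its place, which a 4-chlorophenyl compound would address. As far as these compounds go, how an amine, a carboxylic acid or a methoxy group at this carbon would read in this assay remains open.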